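Triazole benzamides: methyl moved on the benzamide ring

The source may report more compounds than this note shows. Statements on the series, on what has been measured and on what is new or still open speak of the compounds shown alone.

Measured so far:
compound 1 `Cn1c(OCC(C)(C)C(=O)Nc2ccccc2)nnc1-c1ccc(NC(=O)c2ccc3ccccc3c2)cc1` in this assay: 220 nM
compound 2 `Cc1ccc(C(=O)Nc2ccc(-c3nnc(SC(C)C(=O)O)n3C)cc2)cc1` in this assay: > 20000 nM

In an assay on 3T3-L1 cells for inhibition of diacylglycerol O-acyltransferase 1 (Mus musculus) (on this read-out higher numbers stand for weaker inhibition and lower numbers for stronger inhibition), compound 1 gives 220 nM. Compound 2 gives > 20000 nM, which is a limit of the assay and not a number. Going by the values given here, compound 2 therefore sits at the limit of > 20000 nM in this assay, at which 1 of the 2 values shown sits; of the two measured compounds it is the one without a number, and nothing more can be said of where it stands. Among the compounds with values here, the two measured compounds differ in several places, so no single step between them can be read.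

Compound 3 `Cc1ccccc1C(=O)Nc1ccc(-c2nnc(SC(C)C(=O)O)n2C)cc1` is not yet measured in this assay. It differs from compound 2 by 2-methylphenyl in place of 4-methylphenyl on a carbonyl carbon. The step that the limit leaves unreadable from compound 2 to compound 3 is expected to be none beyond the scatter. Compound 3 is estimated at 30000 nM, with a range from 8000 nM to 100000 nM, and most probably the assay will again report only a limit for compound 3.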

Compound 3, half-maximal inhibitory concentration: > 20000 nM
Compound 3 gave a limit, no number; the forecaster's own chance of this, stated with the estimate: 80%; the middle value does not contradict the limit.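

Compound 2 and compound 3 each give only a limit, not a number, in this assay, so no step between them can be read: the limit of > 20000 nM in this assay, at which 2 of the 3 values shown sit.

On these data alone, whether 2-methylphenyl in place of 4-methylphenyl on a carbonyl carbon changes inhibition at all in this assay stays open.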